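Furan-2-yl in place of 2-methoxyphenyl

The source may report more compounds than this note shows. Statements on the series, on what has been measured and on what is new or still open speak of the compounds shown alone.

Measured in a functional assay on MDA-MB-231 cells (Homo sapiens) for inhibition, read by CCK-8 assay, with a stated time of 48 h; on this read-out higher numbers stand for weaker inhibition of growth and lower numbers for stronger inhibition of growth:
compound 1 `Cc1ccccc1Nc1nc(Nc2ccc(N3CCN(C)CC3)cn2)ncc1Cl`: 7470 nM
compound 2 `Cc1ccc(CNc2nc(Nc3ccc(N4CCN(C)CC4)cn3)ncc2Cl)cc1`: 18600 nM
compound 3 `COc1ccccc1CNc1nc(Nc2ccc(N3CCN(C)CC3)cn2)ncc1Cl`: 29300 nM

Two measured steps place compound 3: there is a 3.9-fold higher number from compound 1 to compound 3 (0.59 log units; beyond the scatter), but only a 1.6-fold higher number from compound 2 to compound 3 (0.20 log units; within the scatter). Compound 4 `CN1CCN(c2ccc(Nc3ncc(Cl)c(NCc4ccco4)n3)nc2)CC1` has not yet been measured, and its difference from compound 3 is furan-2-yl in place of 2-methoxyphenyl on a saturated chain carbon bound to a nitrogen on an aromatic ring. Among the measured compounds shown here, no measured step brings in furan-2-yl. The closest guide is the exchange at the same place that links compound 2 and compound 3, a 1.6-fold higher number from compound 2 to compound 3 (0.20 log units; within the scatter), so no step beyond the scatter is expected here. The expected change is a 1.2-fold lower number from compound 3 to compound 4 (0.09 log units; within the scatter). For compound 4 the estimate is 24000 nM, with an expected range of 11000 nM to 50000 nM.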

Compound 4, concentration for 50% growth inhibition: 11000 nM
The estimate for compound 4 lay 2.2-fold (0.34 log units) above the measured number, within the range that was stated.
By their numbers in this assay, from the lowest: compounds 1, 4, 2 and 3 (each within the scatter of the next, the first and the last beyond it).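

At this place, on a saturated chain carbon bound to a nitrogen on an aromatic ring, the exchange linking the two benzyl compounds stayed within the scatter, whereas furan-2-yl gives a step beyond it (a 2.7-fold lower number from compound 3 to compound 4 (0.43 log units; beyond the scatter)). Two steps stay within the scatter (a 1.7-fold lower number from compound 2 to compound 4 (0.23 log units; within the scatter) and a 1.5-fold higher number from compound 1 to compound 4 (0.17 log units; within the scatter)), so only compound 3 separates from compound 4. Nothing available explains this difference. The compounds shown leave open whether thiophen-2-yl, pyridin-2-yl or a simple alkyl chain at this place would follow furan-2-yl or 2-methoxyphenyl.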